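The source may hold more compounds than are shown below. What is called first, only, known or untested is meant among the compounds shown, and "the series" means these compounds.

Three compounds have been measured in a functional assay on HCT-116 cells (Homo sapiens) for cytotoxicity, read by MTT assay, with a stated time of 48 h; a lower number here means a stronger inhibitor, a higher number a weaker inhibitor:

compound 1 `CN(C)CCCCCSC1=Nc2ccccc2C(CC(=O)NCc2ccccc2)N1c1ccc(-c2ccccc2)cc1` gives 9600 nM
compound 2 `O=C(CC1c2ccccc2N=C(SCCCCCN2CCCC2)N1c1ccc(-c2ccc(F)cc2)cc1)NCc1ccc(F)cc1` gives 7700 nM
compound 3 `O=C(CC1c2ccccc2N=C(SCCCCCN2CCCC2)N1c1ccc(-c2ccc(F)cc2)cc1)NCc1ccccc1` gives 12500 nM

Compound 2 and compound 3 share one core and differ by a single change, (fluoro in place of hydrogen on an aromatic carbon), which made the step of a 1.6-fold lower number from compound 3 to compound 2 (0.21 log units; within the scatter). Compound 1 is built on a different core; the difference between the two cores is not broken down here. The numbers for compound 1 and compound 2 lie within the scatter of each other, as do those for compound 1 and compound 3, so no order among the three can be read from them.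

Compound 4 `CN(C)CCCCCSC1=Nc2ccccc2C(CC(=O)NCc2ccc(F)cc2)N1c1ccc(-c2ccccc2)cc1` is not yet measured. It stands to compound 1 exactly as compound 2 stands to compound 3: the change is fluoro in place of hydrogen on an aromatic carbon, at a place described in the same words as for the pair already measured, so it is the same change on another core. For the measured compounds named here, the only guide is the step from compound 3 to compound 2, which was within the scatter. The expectation is therefore a step of about a 1.4-fold lower number from compound 1 to compound 4 (0.14 log units; within the scatter), resting on a 1.6-fold lower number from compound 3 to compound 2 (0.21 log units; within the scatter). Compound 4 is estimated at 7000 nM, between 3500 nM and 14000 nM.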

Compound 4, half-maximal inhibitory concentration: 6400 nM
Beside the measured number, compound 4's estimate is 1.1-fold (0.04 log units) above it, and the stated range covers the measured number.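

In this assay, putting fluoro in place of hydrogen on the benzyl group, so that benzyl becomes 4-fluorobenzyl, gives a 1.5-fold lower number from compound 1 to compound 4 (0.18 log units; within the scatter). Set beside the same change on the other core, the two steps match in size: the same change on two cores in this assay, a 1.6-fold lower number (0.21 log units; within the scatter) from compound 3 to compound 2 and a 1.5-fold lower number (0.18 log units; within the scatter) from compound 1 to compound 4, 1.1-fold (0.03 log units) apart, within the scatter of two such steps

The change therefore carries from one core to the other without any visible difference, but this is a narrow finding: each step lies within the usual scatter of repeated measurements, so neither step alone shows that fluoro changes the number at all, and two matching steps on two cores cannot establish a rule for the whole series.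

The compounds shown leave open whether a larger group at the same place, such as chloro, methoxy or trifluoromethyl, would give a step beyond the scatter. They also leave open whether the same step would hold with another amine at the end of the chain, such as morpholine or piperidine.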